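The compounds below may be only part of what the source reports. "The series", "measured", "known", "first", "only" and "open" are said of these compounds alone.

Working notes on the series. In a functional assay on KYSE-450 cells (Homo sapiens) for inhibition, read by MTT assay, with a stated time of 48 h (on this read-out lower numbers stand for stronger inhibition and higher numbers for weaker inhibition), compound 1 `C=C(C)C(=O)N(Cc1ccc(OC)c(O)c1)c1cc(OC)c(OC)c(OC)c1` gives 200 nM, the lowest of the three numbers in hand. Compound 3 `C/C=C/C(=O)N(Cc1ccc(OC)c(C)c1)c1cc(OC)c(OC)c(OC)c1` gives 32900 nM and compound 2 `COc1ccc(CNc2cc(OC)c(OC)c(OC)c2)cc1F` gives 46200 nM; each of these stands beyond the scatter from compound 1. Compound 4 `COc1ccc(CN(C(=O)CCl)c2cc(OC)c(OC)c(OC)c2)cc1O` awaits measurement in this assay. It differs from compound 1 in one place: chloromethyl in place of 1-methylethenyl on a carbonyl carbon. For the measured compounds named here, no step between two measured compounds covers this change, so the expectation rests on compound 1 alone. Compound 1 serves as the anchor, and a modest step towards weaker inhibition, a 2.0-fold higher number from compound 1 to compound 4 (0.30 log units; within the scatter), is expected, small enough that it may still fall within the scatter. Compound 4 is therefore expected near 400 nM, in the range 100 nM to 2000 nM.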

Compound 4, half-maximal inhibitory concentration: 210 nM
Compound 4: middle estimate off by 1.9-fold (0.28 log units), on the high side, within the range that was stated.
By their numbers in this assay, from the lowest: compounds 1 and 4 (each within the scatter of the next); then compounds 3 and 2 (each within the scatter of the next).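

In this assay, chloromethyl in place of 1-methylethenyl on a carbonyl carbon gives a 1.1-fold higher number from compound 1 to compound 4 (0.02 log units; within the scatter), so the two groups cannot be told apart at this position. The double bond outside aromatic rings, present in 1-methylethenyl and absent from chloromethyl, is therefore not needed to keep the number of compound 1 on the shared core. Nothing measured bears on why the two groups read alike.

On these data alone, whether a plain methyl, a longer chain or an amine on this carbonyl carbon would read alike remains open. So does whether the same exchange reads alike on a different core.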